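The source may hold more compounds than are shown below. What is called first, only, known or untested is meant among the compounds shown, and "the series" means these compounds.

Compound 1 `COc1cc(-c2ccnc3cc(-c4ccccc4)nn23)cc(OC)c1OC`: 254 nM
Compound 2 `COc1cc(-c2ccnc3cc(-c4ccc5c(ccn5C)c4)nn23)cc(OC)c1OC`: 3 nM

Within the data shown here, in a functional assay on MCF7 cells (Homo sapiens) for inhibition, read by CCK-8 assay, with a stated time of 48 h (on this read-out lower numbers stand for stronger inhibition and higher numbers for weaker inhibition), compound 2 has the lower of the two numbers so far. Compound 3 `COc1cc(-c2ccnc3cc(-c4ccc(C(F)(F)F)cc4)nn23)cc(OC)c1OC` makes one change to it: 4-(trifluoromethyl)phenyl in place of 1-methyl-1H-indol-5-yl on an aromatic carbon. Among the measured compounds shown here, only one measured step bears on this, a large one: an 85-fold lower number from compound 1 to compound 2 (1.93 log units; beyond the scatter). That step installed the same 1-methyl-1H-indol-5-yl in place of phenyl. Compound 3 gives up that group for a substituted phenyl, so a large rise is expected. The expected change is a 100-fold higher number from compound 2 to compound 3 (2.00 log units; beyond the scatter). Compound 3 is estimated at 300 nM, within an expected range of 60 nM to 1500 nM.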

Compound 3, half-maximal inhibitory concentration: 2440 nM
Compound 3: middle estimate off by 8.1-fold (0.91 log units), on the low side, and the stated range ends below it.
By their numbers in this assay, from the lowest: compound 2; then compound 1; then compound 3.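

The swap at this position gives an 810-fold higher number from compound 2 to compound 3 (2.91 log units; beyond the scatter), so the outcome depends strongly on which ring system sits here. Compound 3 also falls behind the plain phenyl of compound 1: adding trifluoromethyl gives a 9.6-fold higher number from compound 1 to compound 3 (0.98 log units; beyond the scatter), which shows that a substituent on this phenyl can raise the number, whereas the earlier step had shown only a drop. Nothing measured here explains why the number rises.

Still open, going by these compounds, is whether a different group on that phenyl, such as an amine or a nitrile, would also raise the number, or whether this is specific to trifluoromethyl.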